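Aryl ether at the methyl site of the acylguanidine core

The source may report more compounds than this note shows. Statements on the series, on what has been measured and on what is new or still open speak of the compounds shown alone.

Compound 2 `Cc1c(C(=O)N=C(N)N)cc(S(C)(=O)=O)c(C)c1C` gives 55 nM in a functional assay for inhibition of sodium/hydrogen exchanger (Oryctolagus cuniculus); on this read-out higher numbers stand for weaker inhibition and lower numbers for stronger inhibition. Among the compounds with values here, its number is the lowest of the two measured so far, but the gap to compound 1 `Cc1c(C(=O)N=C(N)N)cc(S(C)(=O)=O)c(Cl)c1C`, which gives 58 nM, is within the scatter, so no order between the two can be claimed. Within the data shown here, the one measured step, a 1.1-fold lower number from compound 1 to compound 2 (0.02 log units; within the scatter), concerns the same aromatic carbon that is altered here.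

Compound 3 `Cc1c(C(=O)N=C(N)N)cc(S(C)(=O)=O)c(Oc2cccnc2)c1C` differs from compound 2 by (pyridin-3-yl)oxy in place of methyl on an aromatic carbon. Among the measured compounds shown here, the only measured step on that carbon exchanged two groups of one heavy atom each and stayed within the scatter; nothing measured covers an entry of a ring-bearing ether of this size. The expectation therefore rests on weak ground. A change this large is more likely to move the number than not, and the expected direction is toward a somewhat higher number, that is a 2.2-fold higher number from compound 2 to compound 3 (0.34 log units; beyond the scatter), with a wide range. Compound 3 is estimated at 120 nM in this assay, expected to fall between 30 nM and 500 nM.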

Compound 3, half-maximal inhibitory concentration: 23 nM
Estimate against measurement, compound 3: 5.2-fold (0.72 log units) above; the whole stated range lies above it.
By their numbers in this assay, from the lowest: compound 3; then compounds 2 and 1 (each within the scatter of the next).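

At this aromatic carbon, ortho to a methylsulfonyl group, the core accepts a much larger substituent than methyl or chloro with no loss in this assay: (pyridin-3-yl)oxy in place of methyl gives a 2.4-fold lower number from compound 2 to compound 3 (0.38 log units; beyond the scatter), and in place of chloro it gives a 2.5-fold lower number from compound 1 to compound 3 (0.40 log units; beyond the scatter). The earlier exchange of one-heavy-atom groups at this carbon, a 1.1-fold lower number from compound 1 to compound 2 (0.02 log units; within the scatter), showed no separation, whereas the entry of 7 heavy atoms with one six-membered aromatic ring moves the number beyond the scatter, though only modestly. Nothing measured beyond these numbers bears on why the number falls.

Compound 3 changes the ether oxygen, the ring and the ring nitrogen together, so the contribution of each remains unresolved; methoxy, phenoxy and (pyridin-4-yl)oxy at this carbon would separate these parts. Also open, from the compounds shown here alone, is whether a saturated ring such as piperidine, or an amine in place of the ether oxygen, would keep the lower number seen with compound 3 in this assay.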